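A few compounds are considered here, and "the series" means these few. Any claim that something is new, unique, unknown or untested is made for them only; others in the source may bear on it.

Of the compounds shown here, three built on one shared core have been measured in a functional assay on K562 cells (Homo sapiens) for inhibition, read by sulforhodamine B assay, with a stated time of 48 h; a higher number here means that more compound is tolerated, a lower number that less compound is tolerated. Compound 1 `COc1cc(-c2nn(-c3cccc(NC(=O)Nc4cc(C(F)(F)F)cc(C(F)(F)F)c4)c3)cc2-c2ccncc2)ccc1Cl` reaches only a limit of the assay, > 50000 nM, and not a number. Compound 2 `COc1cc(-c2nn(-c3cccc(NC(=O)c4cccc(C(F)(F)F)c4)c3)cc2-c2ccncc2)ccc1Cl` likewise gives a limit, > 50000 nM. Compound 3 `COc1cc(-c2nn(-c3cccc(NC(=O)Nc4ccc(Cl)c(Cl)c4)c3)cc2-c2ccncc2)ccc1Cl` also sits at a limit, > 50000 nM. Compound 3 thus stands exactly where the other two stand, with no numerical value that would set it apart, and all three share (the limit of > 50000 nM in this assay, at which 3 of the 3 values shown sit).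

Within the data shown here, the one step between measured compounds that differ in a single place, a step that the two limits leave unreadable from compound 2 to compound 3, shows neither a direction nor a size, since both of its ends are limits.

Compound 4 `COc1cc(-c2nn(-c3cccc(NC(=O)Nc4cccc(C(F)(F)F)c4)c3)cc2-c2ccncc2)ccc1Cl` differs from compound 3 in one place: 3-(trifluoromethyl)phenyl in place of 3,4-dichlorophenyl on an amide-type nitrogen. Among the measured compounds shown here, only the step from compound 2 to compound 3 touches a change of this kind, and it is unreadable. With every measured compound at the same limit, the step of a number no higher from compound 3 to compound 4 (the limit leaves the size open) is expected to bring no shift beyond the scatter. Compound 4 is therefore expected to remain at the limit as well, estimated at 50000 nM with a range from 20000 nM to 50000 nM.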

Compound 4, concentration lethal to 50% of the cells: > 50000 nM
Compound 4: no number, only a limit; the forecaster's own chance of this, stated with the estimate: 85%; the middle value sits exactly at the limit.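

Compound 4 sits with compound 1, compound 2 and compound 3 at one shared limit, so the steps from these compounds to compound 4 cannot be read in either size or direction: the limit of > 50000 nM in this assay, at which 4 of the 4 values shown sit.

The compounds shown leave open what number any of the four would give in this assay, and which of these changes, if any, matters there.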